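Thiophen-2-yl in place of 1H-pyrrol-2-yl: an expected step

A few compounds are considered here, and "the series" means these few. Any claim that something is new, unique, unknown or untested is made for them only; others in the source may bear on it.

In a functional assay on NCI-H460 cells (Homo sapiens) for inhibition, read by sulforhodamine B assay, with a stated time of 48 h (a lower number here means a stronger inhibitor of growth, a higher number a weaker inhibitor of growth), compound 1 `CC1=CC[C@H](C(C)(C)NC(=S)NN)CC1` gives only a limit, > 100000 nM. Compound 2 `CC1=CC[C@H](C(C)(C)NC(=S)N/N=C/c2ccccc2)CC1` gives 53900 nM. Compound 3 `CC1=CC[C@H](C(C)(C)NC(=S)N/N=C/c2ccc[nH]2)CC1` gives 57500 nM, the higher of the two numbers, with compound 2 within the scatter of it. The step of an at least 1.7-fold lower number from compound 1 to compound 3 (0.24 log units; that floor lies within the scatter) is bounded by the limit of > 100000 nM in this assay, at which 1 of the 3 values shown sits. The step of a 1.1-fold higher number from compound 2 to compound 3 (0.03 log units; within the scatter) lies within the scatter. Compound 4 `CC1=CC[C@H](C(C)(C)NC(=S)N/N=C/c2cccs2)CC1` differs from compound 3 by thiophen-2-yl in place of 1H-pyrrol-2-yl on a carbon with a double bond to nitrogen. Among the measured compounds shown here, the one measured exchange of the aryl group on that carbon, from compound 2 to compound 3, moved the number by a 1.1-fold higher number from compound 2 to compound 3 (0.03 log units; within the scatter), so no step beyond the scatter is expected here. Compound 4 is therefore estimated at 50000 nM, between 25000 nM and 100000 nM, which would mean a 1.2-fold lower number from compound 3 to compound 4 (0.06 log units; within the scatter).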

Compound 4, concentration for total growth inhibition: 20800 nM
The estimate for compound 4 lay 2.4-fold (0.38 log units) above the measured number, and the stated range ends above it.
By their numbers in this assay, from the lowest: compound 4; then compounds 2 and 3 (each within the scatter of the next). At a limit, above all of these: compound 1.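

In this assay, the group on a carbon with a double bond to nitrogen now shows an effect beyond the scatter, which the exchange of phenyl for 1H-pyrrol-2-yl did not: thiophen-2-yl gives a 2.8-fold lower number from compound 3 to compound 4 (0.44 log units; beyond the scatter) in place of 1H-pyrrol-2-yl and a 2.6-fold lower number from compound 2 to compound 4 (0.41 log units; beyond the scatter) in place of phenyl. Against the unsubstituted end of the series, the result is an at least 4.8-fold lower number from compound 1 to compound 4 (0.68 log units; beyond the scatter) as a bounded step. That step rests on a limit: the limit of > 100000 nM in this assay, at which 1 of the 4 values shown sits. The compounds shown leave open whether the sulfur atom itself matters, which furan-2-yl could test. They also leave open how a methyl or an amine on the thiophen-2-yl ring would read.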